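The source may hold more compounds than are shown below. What is called first, only, known or untested is meant among the compounds shown, and "the series" means these compounds.

Compound 1, whose structure is `COc1nc(C)nc(/N=C(\C)c2ccccc2)n1`, has no number of its own in an ADME assay on Vero cells (Chlorocebus sabaeus) for cytotoxicity, read by MTT assay, with a stated time of 72 h; a lower number here means a stronger inhibitor, a higher number a weaker inhibitor: for compound 1 the entry there is "not determined" (no result reported). A close relative, compound 2 with structure `COc1cccc(/C(C)=N/c2nc(C)nc(OC)n2)c1`, was measured. In this assay compound 2 is reported only as a limit of the assay, > 50 ug/mL, not as a number. This is where compound 1 stands on the numbers shown: nothing measured for itself, and a single neighbouring reading that is the limit of > 50 ug/mL in this assay, at which 1 of the 2 values shown sits.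

The unmeasured compound 3 has structure `COc1nc(C)nc(/N=C(\C)c2ccccc2O)n1`. It differs from compound 1 in one place: hydroxy in place of hydrogen on an aromatic carbon. For the measured compounds named here, no measured pair in this set shows what such a change does to cytotoxicity, so the expected step in this assay from compound 1 to compound 3 is none beyond the usual scatter, in no particular direction. Compound 3 is therefore estimated to be about as weak an inhibitor of cell growth as its relatives, at 60 ug/mL, with a likely range from 25 ug/mL to 200 ug/mL, and most probably reported again only as a limit.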

Compound 3, half-maximal inhibitory concentration: > 50 ug/mL
Compound 3 gave a limit, no number; the forecaster's own chance of this, stated with the estimate: 75%; the middle value is on the limit's open side.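

For the compounds shown here, no step from compound 1 to compound 3 can be read in this assay, as neither compound has a number there. Still open is whether hydroxy in place of hydrogen changes cytotoxicity at all, and how far the compounds' true values lie beyond the one reading they share: the limit of > 50 ug/mL in this assay, at which 2 of the 3 values shown sit.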